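Chain-end swap on the dichlorophenyl compound: notes

This account rests on a few compounds, and the source may have more. Where it says the series, first, only, none or still open, it means among the compounds named here.

Values in a functional assay on LNCaP cells (Homo sapiens) for antiproliferative activity (a higher number here means a weaker inhibitor, a lower number a stronger inhibitor), are as follows:
- compound 1 `Cn1ncc(Cl)c1-c1cc(C(=O)N[C@@H]2CN[C@H](CCCO)C[C@H]2c2ccc(Cl)c(Cl)c2)oc1Cl` gives 210 nM
- compound 2 `Cn1ncc(Cl)c1-c1cc(C(=O)N[C@@H]2CN[C@H](CCO)C[C@H]2c2ccc(F)c(F)c2)oc1Cl` gives 60 nM
- compound 3 `CNC(=O)C[C@@H]1C[C@@H](c2ccc(F)c(F)c2)[C@H](NC(=O)c2cc(-c3c(Cl)cnn3C)c(Cl)o2)CN1` gives 50 nM

Compound 1 has the highest number of the three, and its gaps to compound 2 and to compound 3 both lie beyond the scatter. Both of those compounds carry fluorine where compound 1 carries chlorine, and their side chains differ too, so these gaps cannot be assigned to any single change.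

The next compound is compound 4 `CN(C)CC[C@@H]1C[C@@H](c2ccc(Cl)c(Cl)c2)[C@H](NC(=O)c2cc(-c3c(Cl)cnn3C)c(Cl)o2)CN1`, which keeps the core of compound 1. The change is dimethylamino in place of hydroxymethyl on a saturated chain carbon, two bonds along the chain from a saturated ring carbon and amounts to dimethylamino in place of hydroxymethyl on a saturated chain carbon, two bonds along the chain from a saturated ring carbon. Read one bond further out, this is 3-hydroxypropyl to 2-(dimethylamino)ethyl.

Among the measured compounds shown here, only one measured step bears on this: a 1.2-fold lower number from compound 2 to compound 3 (0.08 log units; within the scatter), with methylcarbamoyl in place of hydroxymethyl. For the measured compounds named here, no measured compound carries dimethylamino, so this guidance is thin, and the range must stay wide. No step beyond the scatter is expected in this assay for this change. The expected step is a 1.2-fold lower number from compound 1 to compound 4 (0.09 log units; within the scatter) and remains an estimate. For compound 4 an estimate of 170 nM is expected, with a range from 60 nM to 480 nM as estimated.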

Compound 4, half-maximal inhibitory concentration: 1930 nM
Estimate against measurement, compound 4: 11-fold (1.06 log units) below; measured number above the stated range.
By their numbers in this assay, from the lowest: compounds 3 and 2 (each within the scatter of the next); then compound 1; then compound 4.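

In this assay the chain end on the dichlorophenyl compound proves sensitive to which group sits there: a 9.2-fold higher number from compound 1 to compound 4 (0.96 log units; beyond the scatter), with dimethylamino in place of hydroxymethyl on a saturated chain carbon, two bonds along the chain from a saturated ring carbon. Among the compounds shown here, the only earlier chain-end step, a 1.2-fold lower number from compound 2 to compound 3 (0.08 log units; within the scatter), lies within the scatter, so a swap at this end of the chain is now seen both to leave the number unchanged within the scatter and to move it beyond the scatter, although the two pairs carry different halogens on the phenyl ring and different incoming groups. No measurement at hand explains the size of the new step.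

A 2-aminoethyl or a 2-methoxyethyl chain on the core of compound 1 would help separate the arrival of the amine nitrogen and its methyl groups from the departure of the hydroxyl. From the compounds shown here alone, it also remains open whether the 2-(dimethylamino)ethyl chain gives a step of similar size on the difluorophenyl compounds, or whether this step holds only with the dichlorophenyl group.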